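Meta or Para Trifluoromethyl on a Shared Pyridine-Type Core

The source may hold more compounds than are shown below. What is called first, only, known or untested is meant among the compounds shown, and "the series" means these compounds.

Compound 1 `Oc1ccc(-c2cc(-c3cccc(C(F)(F)F)c3)cc(-c3ccccc3O)n2)cc1` and compound 3 `Oc1ccc(-c2cc(-c3cccc(C(F)(F)F)c3)cc(-c3cccc(O)c3)n2)cc1` share one core but differ, as counted in 3-hydroxyphenyl in place of 2-hydroxyphenyl on an aromatic carbon. In a functional assay on HCT-15 cells (Homo sapiens) for inhibition (a higher number here means a weaker inhibitor, a lower number a stronger inhibitor), compound 1 is reported only as a limit, > 50000 nM. Compound 3 gives 9540 nM in this assay, the step being an at least 5.2-fold lower number from compound 1 to compound 3 (0.71 log units; beyond the scatter). Compound 2 `Oc1ccc(-c2cc(-c3ccc(C(F)(F)F)cc3)cc(-c3ccccc3O)n2)cc1` differs from compound 1 by 4-(trifluoromethyl)phenyl in place of 3-(trifluoromethyl)phenyl on an aromatic carbon; in this assay compound 2 is likewise only a limit, > 50000 nM, so the step is a step that the two limits leave unreadable from compound 1 to compound 2, both values sitting at the limit of > 50000 nM in this assay, at which 2 of the 3 values shown sit. Compound 4 `Oc1ccc(-c2cc(-c3ccc(C(F)(F)F)cc3)cc(-c3cccc(O)c3)n2)cc1` carries the same kind of change relative to compound 3, (4-(trifluoromethyl)phenyl in place of 3-(trifluoromethyl)phenyl on an aromatic carbon), the surroundings differing in that the place is meta to a 3-hydroxyphenyl group rather than a 2-hydroxyphenyl group. Because compound 3 gives 9540 nM and the earlier step is unreadable, compound 4 is expected near 12000 nM, between 4000 nM and 40000 nM. The step expected from compound 3 is a 1.3-fold higher number from compound 3 to compound 4 (0.10 log units; within the scatter).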

Compound 4, half-maximal inhibitory concentration: 6440 nM
Estimate against measurement, compound 4: 1.9-fold (0.27 log units) above; the range from low to high includes it.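

In this assay, the swap to 4-(trifluoromethyl)phenyl gives a 1.5-fold lower number from compound 3 to compound 4 (0.17 log units; within the scatter), so on this core the two trifluoromethyl placements cannot be told apart. The change from 2-hydroxyphenyl to 3-hydroxyphenyl gives an at least 7.7-fold lower number from compound 2 to compound 4 (0.89 log units; beyond the scatter), and it points the same way on both cores, though its size on each is only bounded: the same change on two cores in this assay, an at least 5.2-fold lower number (0.71 log units; beyond the scatter) from compound 1 to compound 3 and an at least 7.7-fold lower number (0.89 log units; beyond the scatter) from compound 2 to compound 4; the limit leaves it open whether they differ The trifluoromethyl swap from compound 1 to compound 2 cannot be read, so whether that swap carries from one core to the other stays unknown: the limit of > 50000 nM in this assay, at which 2 of the 4 values shown sit.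

The compounds shown leave open whether the hydroxyphenyl step would hold with a nitrile or a carboxylic acid in place of trifluoromethyl. They also leave open what an amine in place of the hydroxyl would do.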